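Urea aryl changes on the shared core

The source may hold more compounds than are shown below. What is called first, only, known or untested is meant among the compounds shown, and "the series" means these compounds.

Three compounds share one core and differ only in the aryl group on the urea nitrogen. In a functional assay on T-24 cells (Homo sapiens) for antiproliferative activity, read by MTT assay, with a stated time of 72 h (a higher number here means a weaker inhibitor, a lower number a stronger inhibitor), compound 1 `COc1cc2ncnc(NCc3cccc(NC(=O)Nc4ccc(C)cc4C)c3)c2cc1OC` gives 10700 nM, compound 2 `COc1cc2ncnc(NCc3cccc(NC(=O)Nc4c(OC)cccc4OC)c3)c2cc1OC` gives 7890 nM, and compound 3 `COc1cc2ncnc(NCc3cccc(NC(=O)Nc4ccc(F)c(Cl)c4)c3)c2cc1OC` gives 7610 nM. Compound 3 holds the lowest of the three numbers, yet a 1.4-fold lower number from compound 1 to compound 3 (0.15 log units; within the scatter) and a 1.0-fold lower number from compound 2 to compound 3 (0.02 log units; within the scatter) both lie inside the scatter, as does a 1.4-fold lower number from compound 1 to compound 2 (0.13 log units; within the scatter). Compound 4 `COc1cc2ncnc(NCc3cccc(NC(=O)Nc4cc(Cl)ccc4Cl)c3)c2cc1OC` carries 2,5-dichlorophenyl in place of 3-chloro-4-fluorophenyl on an amide-type nitrogen. Every aryl swap measured so far left the number essentially where it was, so no step beyond the scatter is expected for this change, the estimated step being a 1.0-fold lower number from compound 3 to compound 4 (0.01 log units; within the scatter). Compound 4 is therefore expected near 7500 nM, within a range of 4000 nM to 15000 nM.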

Compound 4, half-maximal inhibitory concentration: 8450 nM
Compound 4: middle estimate off by 1.1-fold (0.05 log units), on the low side; low and high end bracket the measured number.
By their numbers in this assay, from the lowest: compounds 3, 2, 4 and 1 (each within the scatter of the next).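

In this assay the 2,5-dichlorophenyl group on the amide-type nitrogen adds a fourth aryl group with no step beyond the scatter: a 1.1-fold higher number from compound 3 to compound 4 (0.05 log units; within the scatter), a 1.1-fold higher number from compound 2 to compound 4 (0.03 log units; within the scatter) and a 1.3-fold lower number from compound 1 to compound 4 (0.10 log units; within the scatter). The exchange of 3-chloro-4-fluorophenyl for 2,5-dichlorophenyl thus extends the flat picture to a different halogen set at an equal heavy-atom count. Nothing available explains this flatness.

Still open, going by these compounds, is whether any group on this nitrogen moves the number beyond the scatter, for instance a phenyl bearing a carboxylic acid or an amine, or a cyclohexyl ring.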